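Swapping the aryl group on a shared core: compound 4

This account rests on a few compounds, and the source may have more. Where it says the series, first, only, none or still open, it means among the compounds named here.

Measured compounds:
- compound 1 `COc1ccc(-c2c(O)nc3cc(Cl)c([N+](=O)[O-])cc3c2OCCC2CCCCN2)cc1OC`: 600 nM
- compound 2 `Cc1cc(-c2c(O)nc3cc(Cl)c([N+](=O)[O-])cc3c2OCCC2CCCCN2)cc(C(C)O)c1`: 63 nM
- compound 3 `O=[N+]([O-])c1cc2c(OCCC3CCCCN3)c(-c3cccs3)c(O)nc2cc1Cl`: 220 nM

The three measured compounds share one core and differ only in the aryl group attached to a single aromatic carbon. In a functional assay on cells (Pituitary gland cell) for antagonist activity at Gonadotropin-releasing hormone receptor (Rattus norvegicus) (a higher number here means a weaker inhibitor, a lower number a stronger inhibitor), compound 1 gives 600 nM, the highest of the three numbers. The nearest number is reached by a 2.7-fold lower number from compound 1 to compound 3 (0.44 log units; beyond the scatter), and the furthest by a 9.5-fold lower number from compound 1 to compound 2 (0.98 log units; beyond the scatter), both beyond the scatter.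

Compound 4 `O=[N+]([O-])c1cccc(-c2c(O)nc3cc(Cl)c([N+](=O)[O-])cc3c2OCCC2CCCCN2)c1` has not been measured. It differs from compound 1 by 3-nitrophenyl in place of 3,4-dimethoxyphenyl on an aromatic carbon. For the measured compounds named here, two measured steps bear on this change, since each replaces the same 3,4-dimethoxyphenyl group: a 9.5-fold lower number from compound 1 to compound 2 (0.98 log units; beyond the scatter) and a 2.7-fold lower number from compound 1 to compound 3 (0.44 log units; beyond the scatter). Both are modest and both lower the number. Neither replacement resembles 3-nitrophenyl closely, so the size is uncertain, but a modest downward step is expected here too, about a 2.7-fold lower number from compound 1 to compound 4 (0.44 log units; beyond the scatter). Compound 4 is therefore estimated at 220 nM in this assay, with a range from 70 nM to 700 nM.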

Compound 4, half-maximal inhibitory concentration: 100 nM
Compound 4: the middle estimate sits 2.2-fold (0.34 log units) above what was measured; the measured number falls inside the stated range.
By their numbers in this assay, from the lowest: compounds 2 and 4 (each within the scatter of the next); then compound 3; then compound 1.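

In this assay, 3-nitrophenyl on this aromatic carbon gives a 6.0-fold lower number from compound 1 to compound 4 (0.78 log units; beyond the scatter), and it also improves on the five-membered thiophen-2-yl ring, with a 2.2-fold lower number from compound 3 to compound 4 (0.34 log units; beyond the scatter). Set against the best earlier group, the change gives a 1.6-fold higher number from compound 2 to compound 4 (0.20 log units; within the scatter), so 3-nitrophenyl and 3-(1-hydroxyethyl)-5-methylphenyl cannot be told apart here. Since 3-nitrophenyl has no hydrogen-bond donors, the hydroxy group of compound 2 is not required to reach this level of inhibition at this position.

No measurement shown explains why these aryl groups give different numbers. As far as these compounds go, it remains open what a plain phenyl ring would give, and whether an amine or a carboxylic acid in place of the nitro group would keep the number of compound 4.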